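Methoxycarbonyl to carboxy: expectation for compound 4

The source may hold more compounds than are shown below. What is called first, only, known or untested is meant among the compounds shown, and "the series" means these compounds.

Compound 1 `COC(=O)c1c(-c2cc(OC)cc(OC)c2)oc2ccccc2c1=O` carries a methoxycarbonyl group. In a functional assay on Malme-3M cells (Homo sapiens) for cytotoxicity, read by MTT assay, with a stated time of 6 days (a higher number here means that more compound is needed for the effect, a lower number that less compound is needed), compound 1 gives only a limit, > 25 ug/mL. Compound 3 `COc1cc(OC)cc(-c2oc3ccccc3c(=O)c2C(=O)O)c1` is its carboxy partner, the change being (hydrogen in place of methyl on an oxygen next to a carbonyl group). In this assay compound 3 likewise gives only a limit, > 25 ug/mL. Both sitting at the limit, the step that the two limits leave unreadable from compound 1 to compound 3 cannot be read. Compound 2 `COC(=O)c1c(-c2ccc([N+](=O)[O-])cc2)oc2ccccc2c1=O` carries the same methoxycarbonyl group on another core; the difference between the two cores is not broken down here. In this assay compound 2 also gives only a limit, > 25 ug/mL. All three values thus fall together: the limit of > 25 ug/mL in this assay, at which 3 of the 3 values shown sit.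

Compound 4 `O=C(O)c1c(-c2ccc([N+](=O)[O-])cc2)oc2ccccc2c1=O` has not yet been measured and is the carboxy analogue of compound 2; the change is hydrogen in place of methyl on an oxygen next to a carbonyl group, the same change as that from compound 1 to compound 3, at a place described in identical words. The expectation for compound 4 rests on compound 2 giving only a limit, > 25 ug/mL, and on the step that the two limits leave unreadable from compound 1 to compound 3 having no readable size. Compound 4 is therefore expected to stay near the limit, with an expected step that the limit leaves unreadable from compound 2 to compound 4. Compound 4 is estimated at 30 ug/mL, between 20 ug/mL and 60 ug/mL, and most probably reported only as a limit.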

Compound 4, concentration for half-maximal effect: > 25 ug/mL
Compound 4: only a limit was reported; the forecaster's own chance of this, stated with the estimate: 85%; the middle value lies beyond the limit too.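

Compound 2 and compound 4 both give only a limit in this assay, so no step from methoxycarbonyl to carboxy can be read between them: the limit of > 25 ug/mL in this assay, at which 4 of the 4 values shown sit.

The compounds shown leave open what concentration any of the four needs for half-maximal effect in this assay, and whether methoxycarbonyl and carboxy differ at all on either core.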